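Paw edema inhibition across three aryl variants of one core

This account rests on a few compounds, and the source may have more. Where it says the series, first, only, none or still open, it means among the compounds named here.

Compound 1 `Cc1ccc(C2=NN(c3ccc(S(C)(=O)=O)cc3)C(=O)CC2)cc1` gives 60.5% in a functional assay on the whole organism (strain Wistar) for inhibition, with Rattus norvegicus as the target, read by paw edema, with stated times of 30 min and 5 h, at a dose of 0.05 mmol/kg by the oral route; a higher number here means more inhibition at the dose given (going by the name of the read-out), a lower number less inhibition. Compound 2 `Cc1cc(C2=NN(c3ccc(S(C)(=O)=O)cc3)C(=O)CC2)ccc1O` gives 60.5% in this assay, and the step of no change at the digits printed from compound 1 to compound 2 (within the scatter) is within the scatter; compound 2 thus stands level with compound 1. Compound 3 `CS(=O)(=O)c1ccc(N2N=C(c3ccccc3)CCC2=O)cc1` is not yet measured and differs from compound 2 by phenyl in place of 4-hydroxy-3-methylphenyl on a carbon with a double bond to nitrogen. For the measured compounds named here, only the step from compound 1 to compound 2 bears on this, and it showed no change, so a step of a number 5.5 percentage points lower from compound 2 to compound 3 (within the scatter) is expected, with no change beyond the scatter. Compound 3 is therefore estimated at 55% in this assay, with a range from 38% to 70%.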

Compound 3, a percentage reported as inhibition, in the whole organism at one dose (the size of the read-out at that dose, not a potency): 47.3%
Beside the measured number, compound 3's estimate is 7.7 percentage points above it; low and high end bracket the measured number.
By their numbers in this assay, from the lowest: compound 3; then compounds 1 and 2 (each within the scatter of the next).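

For the compounds shown here, the aryl group on the carbon with a double bond to nitrogen does affect the result in this assay: phenyl in place of 4-hydroxy-3-methylphenyl gives a number 13.2 percentage points lower from compound 2 to compound 3 (beyond the scatter), the first step here beyond the scatter. Hydrogen in place of the methyl alone gives a number 13.2 percentage points lower from compound 1 to compound 3 (beyond the scatter), so this single group accounts for a modest drop. Nothing measured explains the drop.

As far as these compounds go, it remains open whether a methoxy group or a chlorine in place of that methyl would hold the level of compound 1, and whether a 4-hydroxyphenyl without the methyl would do so.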